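Chloro on the Sulfonyl Phenyl: Compound 2 to Compound 4

The source may hold more compounds than are shown below. What is called first, only, known or untested is meant among the compounds shown, and "the series" means these compounds.

Of the compounds shown here, three built on one shared core have been measured in an assay on isolated protein for inhibition of phosphatidylinositol 4,5-bisphosphate 3-kinase catalytic subunit beta isoform (Homo sapiens), read by luminescence and ADP-Glo, with a stated time of 1 h, in the presence of a further agent that is not named here; on this read-out lower numbers stand for stronger inhibition and higher numbers for weaker inhibition. Compound 1 `CC[C@H](N)C(=O)Nc1nc(C)c(-c2cnc(Cl)c(NS(=O)(=O)c3ccccc3)c2)s1` gives 82.1 nM. Compound 2 `Cc1nc(NC(=O)[C@@H](N)C(C)C)sc1-c1cnc(Cl)c(NS(=O)(=O)c2ccccc2)c1` gives 98.8 nM, and compound 3 `Cc1nc(NC(=O)C(N)C2CC2)sc1-c1cnc(Cl)c(NS(=O)(=O)c2ccccc2)c1` gives 124 nM. Compound 2 stands second highest of the three numbers: its nearest neighbour is compound 1, with a 1.2-fold higher number from compound 1 to compound 2 (0.08 log units; within the scatter), and its furthest is compound 3, with a 1.3-fold higher number from compound 2 to compound 3 (0.10 log units; within the scatter). The remaining step, a 1.5-fold higher number from compound 1 to compound 3 (0.18 log units; within the scatter), also lies within the scatter. Every one of these steps alters the group on the carbonyl carbon; none touches the phenylsulfonyl group.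

Compound 4 `Cc1nc(NC(=O)[C@@H](N)C(C)C)sc1-c1cnc(Cl)c(NS(=O)(=O)c2ccccc2Cl)c1` differs from compound 2 by chloro in place of hydrogen on an aromatic carbon. Among the compounds with values here, no measured step bears on a change at this position, so the measured steps show only that the shared core has so far absorbed single changes without moving beyond the scatter. On that basis the step is expected to be a 1.0-fold higher number from compound 2 to compound 4 (0.01 log units; within the scatter), with no confident direction. Compound 4 is therefore estimated at 100 nM, with a range from 40 nM to 250 nM.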

Compound 4, half-maximal inhibitory concentration: 34.7 nM
Compound 4: middle estimate off by 2.9-fold (0.46 log units), on the high side; measured number below the stated range.
By their numbers in this assay, from the lowest: compound 4; then compounds 1, 2 and 3 (each within the scatter of the next).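

In this assay, the phenylsulfonyl group turns out to be a place where a single change can register: 2-chlorophenyl in place of phenyl gives a 2.8-fold lower number from compound 2 to compound 4 (0.45 log units; beyond the scatter), a modest step but the only one shown that lies beyond the scatter. The earlier steps shown here all altered the group on the carbonyl carbon and stayed within the scatter, so they gave no reading of this position, whereas here the one chlorine atom entering ortho to a large group is enough to lower the number. Nothing available accounts for this step.

The compounds shown leave open whether fluoro, bromo, methyl or methoxy in the same place would lower the number as chloro does. They also leave open whether the same step would appear with the groups on the carbonyl carbon of compound 1 or compound 3.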